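The source may report more compounds than this note shows. Statements on the series, on what has been measured and on what is new or still open speak of the compounds shown alone.

Compound 1 `COc1cc(/C=C/C(=O)c2cccc(NC(=O)c3ccco3)c2)ccc1O` gives 3.11 ug/mL in a functional assay on Vero cells (Chlorocebus sabaeus) for inhibition (on this read-out lower numbers stand for stronger inhibition and higher numbers for weaker inhibition), the lowest of the three numbers, yet every step away from it stays within the scatter. Compound 2 `COc1cc(/C=C/C(=O)c2cccc(N)c2)ccc1O` gives 6.02 ug/mL, and compound 3 `COC(=O)C(=O)Nc1cccc(C(=O)/C=C/c2ccc(O)c(OC)c2)c1` gives 3.55 ug/mL. Compound 4 `CCCC(=O)Nc1cccc(C(=O)/C=C/c2ccc(O)c(OC)c2)c1` is not yet measured; it differs from compound 1 by propyl in place of furan-2-yl on a carbonyl carbon. Within the data shown here, two measured steps bear on this change: removing the whole acyl group, a 1.9-fold higher number from compound 1 to compound 2 (0.29 log units; within the scatter), and exchanging the group on the carbonyl carbon, a 1.1-fold higher number from compound 1 to compound 3 (0.06 log units; within the scatter). Both stay within the scatter, so among these compounds the group on the carbonyl carbon changes the read-out little. For compound 4 the expected step is a 1.1-fold higher number from compound 1 to compound 4 (0.05 log units; within the scatter), no larger than the scatter. Compound 4 is estimated at 3.5 ug/mL, between 1.8 ug/mL and 7 ug/mL.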

Compound 4, half-maximal inhibitory concentration: 2.04 ug/mL
The estimate for compound 4 lay 1.7-fold (0.23 log units) above the measured number; the measured number falls inside the stated range.
By their numbers in this assay, from the lowest: compounds 4, 1, 3 and 2 (each within the scatter of the next, the first and the last beyond it).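

Propyl has no ring, yet a 1.5-fold lower number from compound 1 to compound 4 (0.18 log units; within the scatter) and a 1.7-fold lower number from compound 3 to compound 4 (0.24 log units; within the scatter) are both within the scatter, so in this assay neither furan-2-yl nor methoxycarbonyl proves necessary on this carbonyl carbon among these compounds. With a 3.0-fold lower number from compound 2 to compound 4 (0.47 log units; beyond the scatter) the shown series gains its first step beyond the scatter, a modest separation between hydrogen and propylcarbonyl on the nitrogen. Nothing available gives a reason for these steps. Still open, from the compounds shown here alone, is whether a longer chain such as hexyl would hold this level, and whether an amine or a carboxylic acid at the end of the chain would.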